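One Stereocentre Flipped: From Compound 3 to Compound 4

The compounds below may be only part of what the source reports. "The series", "measured", "known", "first", "only" and "open" are said of these compounds alone.

Measured so far:
Compound 1, `CCCCCCCCO[C@H]1O[C@@H]2COC(=O)CC/C=C/CCC(=O)O[C@H]2[C@H](OC)[C@H]1OC`: 91400 nM
Compound 2, `CCCCCCCCO[C@H]1O[C@@H]2COC(=O)CCCCCCC(=O)O[C@H]2[C@H](O)[C@H]1O`: 38100 nM
Compound 3, `CCCCCCCCO[C@H]1O[C@H](CO)[C@@H](O)[C@H](OCc2ccccc2)[C@H]1OCc1ccccc1`: 52900 nM

All three numbers come from a functional assay on BT-20 cells (Homo sapiens) for antiproliferative activity, read by MTT assay, with a stated time of 48 h; a higher number here means a weaker inhibitor, a lower number a stronger inhibitor. Compound 3 is the one to start from. Its value is bracketed by those of compound 2 and compound 1, and both gaps fall within the usual scatter of this measurement, so on these numbers the three compounds cannot be told apart: none is clearly stronger or weaker than another.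

Compound 4, `CCCCCCCCO[C@@H]1O[C@H](CO)[C@@H](O)[C@H](OCc2ccccc2)[C@H]1OCc1ccccc1`, is the next step. Compared with compound 3, (the two compounds have the same atoms and bonds and differ only in configuration as drawn: 1 of 5 stereo elements differ; a stereocentre at a saturated ring carbon is drawn S in compound 3 and R in compound 4). Nothing is added and nothing is removed; only the handedness at one ring carbon is changed. Among the measured compounds shown here, no pair of measured compounds shows what such a flip alone does here, so there is no measured step to lean on. Since the three measured compounds already differ more in their atoms than compound 3 and compound 4 do, yet stay within the scatter of one another, the expectation is that this single change will not move the number beyond the scatter either. Compound 4 is therefore expected to give about 55000 nM in this assay, with a likely range from 20000 nM to 150000 nM. This estimate means an expected step of a 1.0-fold higher number from compound 3 to compound 4 (0.02 log units; within the scatter), which is no step beyond the scatter.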

Compound 4, half-maximal inhibitory concentration: 61100 nM
Compound 4: middle estimate off by 1.1-fold (0.05 log units), on the low side; low and high end bracket the measured number.
By their numbers in this assay, from the lowest: compounds 2, 3, 4 and 1 (each within the scatter of the next, the first and the last beyond it).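

This pair gives the first clean reading of a single change in the series, because nothing else varies between the two structures: the fact that compounds 3 and 4 differ only in the configuration as drawn

In this assay, turning the saturated ring carbon from S to R gives a 1.2-fold higher number from compound 3 to compound 4 (0.06 log units; within the scatter), which lies within the scatter, so the two compounds cannot be told apart. The earlier compounds shown here differ from one another in more than one place and could say nothing about this carbon on its own, whereas there is now a measured result: on this core, the handedness at this one position does not shift the number beyond the usual noise of the measurement.

As far as these compounds go, that result holds for this one pair and this one cell-based read-out, so it remains open whether the same flip would also leave the number unchanged on the core of compound 1 or the core of compound 2. From the compounds shown here alone, it is also open whether this carbon would matter more with a different group on the shared core, for example an amine or a carboxylic acid in place of a free hydroxyl group.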